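Benzyl variation on the orexin-2 sulfonylurea series

The compounds below may be only part of what the source reports. "The series", "measured", "known", "first", "only" and "open" are said of these compounds alone.

Measured so far:
compound 1 `COc1ccc(N2C(=O)N(Cc3c(F)cc(F)cc3OC)c3ccccc3S2(=O)=O)cc1OC` — 6.31 nM
compound 2 `COc1cc(N2C(=O)N(Cc3c(F)cc(F)cc3Cl)c3ccccc3S2(=O)=O)cnc1OC` — 1.59 nM

In an assay on HEK293 cells for displacement of a labelled ligand from Orexin receptor type 2 (Homo sapiens), read by scintillation counting, with a stated time of 90 min (on this read-out higher numbers stand for weaker inhibition and lower numbers for stronger inhibition), compound 1 gives the higher of the two numbers; compound 2, which differs from it in more than one place, lies beyond the scatter below it. Among the compounds with values here, no single-change step between measured compounds is available. Compound 3 `COc1ccc(N2C(=O)N(Cc3c(F)cc(C)cc3Cl)c3ccccc3S2(=O)=O)cc1OC` carries the change (2-chloro-6-fluoro-4-methylphenyl in place of 2,4-difluoro-6-methoxyphenyl on a saturated chain carbon bound to an amide-type nitrogen in a ring). The expectation is a modest step towards a lower number, of the size a 2.0-fold lower number from compound 1 to compound 3 (0.29 log units; within the scatter), since the only other benzyl variant known here, compound 2, sits lower, though its core also differs. Compound 3 is estimated at 3.2 nM, in the range 1 nM to 10 nM.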

Compound 3, inhibition constant: 0.794 nM
For compound 3 the middle estimate is 4.0-fold (0.61 log units) above the measured one, outside the stated range (below it).
By their numbers in this assay, from the lowest: compounds 3 and 2 (each within the scatter of the next); then compound 1.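

In this assay, the group on a saturated chain carbon bound to an amide-type nitrogen in a ring proves responsive: 2-chloro-6-fluoro-4-methylphenyl in place of 2,4-difluoro-6-methoxyphenyl gives a 7.9-fold lower number from compound 1 to compound 3 (0.90 log units; beyond the scatter) with the shared core unchanged. Within the data shown here, this is the first single-change step, and it credits the whole substituted phenyl, not any one substituent. Nothing measured here explains the step.

Open, on these data alone, is whether the chlorine, the methyl or the absent methoxy carries the step. Also open, as far as these compounds go, is how a nitrile in place of that methyl would read.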